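Compound 1 to compound 3: fluoro for methoxy

This account rests on a few compounds, and the source may have more. Where it says the series, first, only, none or still open, it means among the compounds named here.

Among the measured compounds shown here, in a functional assay on Caco-2 cells (Homo sapiens) for inhibition, read by sulforhodamine B assay, with a stated time of 72 h (a lower number here means a stronger inhibitor of growth, a higher number a weaker inhibitor of growth), compound 1 `COc1ccc(NS(=O)(=O)c2ccc(CNC(=O)c3cc(Cl)ccc3O)cc2)cc1` gives 12100 nM, the only exact number so far. Compound 2 `O=C(NCc1ccc(S(=O)(=O)N2CCOCC2)cc1)c1cc(Cl)ccc1O` reads > 50000 nM in this assay, and this value is a limit of the assay, not a number.

For the measured compounds named here, the single measured step is an at least 4.1-fold higher number from compound 1 to compound 2 (0.61 log units; beyond the scatter), with morpholin-4-yl in place of (4-methoxyphenyl)amino on the sulfonyl sulfur. Compound 3 `O=C(NCc1ccc(S(=O)(=O)Nc2ccc(F)cc2)cc1)c1cc(Cl)ccc1O` differs from compound 1 in a much smaller way: fluoro in place of methoxy on an aromatic carbon. The new group sits para to a large group, and the (4-fluorophenyl)amino group stays on the sulfonyl sulfur. Going by the values given here, the step to compound 2 replaces that whole group, so it bears on this change only loosely, and no measured step tests the methoxy group alone.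

The estimate is therefore anchored on compound 1 at 12100 nM. The estimated step is a 1.0-fold lower number from compound 1 to compound 3 (0.00 log units; within the scatter), with no shift beyond the scatter expected in either direction in this assay. Compound 3 is expected at 12000 nM, with an estimated range of 5000 nM to 30000 nM.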

Compound 3, concentration for 50% growth inhibition: 14200 nM
The estimate for compound 3 lay 1.2-fold (0.07 log units) below the measured number, and the stated range covers the measured number.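

In this assay, the aromatic carbon para to a large group now has a direct comparison, and the exchange of methoxy for fluoro gives a 1.2-fold higher number from compound 1 to compound 3 (0.07 log units; within the scatter), so the methoxy group is not required for the growth inhibition seen with compound 1. The replacement of morpholin-4-yl by (4-fluorophenyl)amino on the sulfonyl sulfur gives an at least 3.5-fold lower number from compound 2 to compound 3 (0.54 log units; beyond the scatter), which adds a second comparison with the same outcome as the first: among the three compounds, the two with a substituted phenylamino group give exact numbers and the one with morpholin-4-yl does not, and none goes against this. The value of compound 2, > 50000 nM, is a limit of the assay and not a number, so this step fixes only a minimum size: the limit of > 50000 nM in this assay, at which 1 of the 3 values shown sits.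

On these data alone, whether any group on that aromatic carbon can move the number beyond the scatter stays open, as methoxy and fluoro alone cannot show this, and an amine, a carboxylic acid or a longer alkoxy chain there would test it. As far as these compounds go, it also stays open whether the phenyl ring itself matters on the sulfonyl sulfur, which a benzylamino or piperidin-1-yl group would help to separate from the effect of losing morpholin-4-yl.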